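This account rests on a few compounds, and the source may have more. Where it says the series, first, only, none or still open, it means among the compounds named here.

Compound 1 `CCCCCCCCCCCCCCCCCCOCC1CC(COCCCCCCC[n+]2ccsc2)CO1`: 2.1 mg/kg
Compound 2 `CCCCCCCCCCCCCCC1COC(COCCCCCC[N+]2(C)C=CN=C2)C1`: a limit, > 5 mg/kg
Compound 3 `CCCCCCCCCCCCOCC1COC(COCCCCCCC[n+]2ccsc2)C1`: 3.7 mg/kg
Compound 4 `CCCCCCCCCCCCCCC1COC(COCCCCCCC[n+]2ccsc2)C1`: not yet measured

In a functional assay on artery with platelet-activating factor receptor (Rattus norvegicus) as the target (on this read-out lower numbers stand for an effect already at smaller amounts and higher numbers for an effect only at larger amounts of compound), compound 1 gives 2.1 mg/kg and compound 3 gives 3.7 mg/kg, two values that lie close together. For compound 2 only a limit is known, > 5 mg/kg, so compound 2 sits at the limit of > 5 mg/kg in this assay, at which 1 of the 3 values shown sits, and no number can be set against it. Compound 4 arises from compound 2 by a group of 6 heavy atoms (4 carbon, 1 nitrogen, 1 sulfur; one five-membered aromatic ring with 2 hetero atoms) in place of a group of 6 heavy atoms (4 carbon, 2 nitrogen; one five-membered non-aromatic ring with 2 hetero atoms), on a saturated chain carbon, six bonds along the chain from an oxygen on a saturated carbon. Going by the values given here, no measured step shows this exact change. Because compound 1 gives 2.1 mg/kg and compound 3 gives 3.7 mg/kg, both carrying the group that enters, the expected step of an at least 1.6-fold lower number from compound 2 to compound 4 (0.22 log units; that floor lies within the scatter) points toward an effect at smaller amounts. Compound 4 is therefore estimated at 3 mg/kg, with a range from 1.5 mg/kg to 6 mg/kg.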

Compound 4, dose for 50% inhibition: 1.5 mg/kg
For compound 4 the middle estimate is 2.0-fold (0.30 log units) above the measured one; measured number inside the range.
By their numbers in this assay, from the lowest: compounds 4, 1 and 3 (each within the scatter of the next, the first and the last beyond it). At a limit, above all of these: compound 2.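

Compounds 2 and 4 give the first direct read of a change at this place, on a saturated chain carbon, six bonds along the chain from an oxygen on a saturated carbon. In this assay, putting the five-membered aromatic ring with 2 hetero atoms in place of the non-aromatic ring gives an at least 3.3-fold lower number from compound 2 to compound 4 (0.52 log units; beyond the scatter). The full size of this step stays unknown because compound 2 has only a limit: the limit of > 5 mg/kg in this assay, at which 1 of the 4 values shown sits.

As far as these compounds go, it remains open how a pyridinium ring or a trimethylammonium group would compare at this place. From the compounds shown here alone, it is also open whether the non-aromatic ring would behave the same way on the cores of compound 1 and compound 3.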